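The source may hold more compounds than are shown below. What is called first, only, known or untested is meant among the compounds shown, and "the series" means these compounds.

Measured compounds and their numbers in a functional assay on HT-29 cells (Homo sapiens) for cytotoxicity, read by MTT assay, with a stated time of 72 h; a lower number here means a stronger inhibitor, a higher number a weaker inhibitor:

Compound 1 `COc1cc2c(Oc3ccc(NC(=O)c4nnn(-c5ccccc5C(F)(F)F)c4C(F)(F)F)cc3F)ccnc2cc1OCCCN1CCCC1`: 210 nM
Compound 2 `COc1cc2c(Oc3ccc(NC(=O)c4nnn(-c5ccccc5)c4C)cc3F)ccnc2cc1OCCCN1CCC(C)CC1`: 140 nM
Compound 3 `COc1cc2c(Oc3ccc(NC(=O)c4nnn(-c5ccccc5C(F)(F)F)c4C(F)(F)F)cc3F)ccnc2cc1OCCCN1CCC(C)CC1`: 200 nM

Compound 3 gives the second highest of the three numbers in this assay; its nearest neighbour is compound 1, and its furthest is compound 2, both within the usual scatter of this assay. For the measured compounds named here, the only single-point step among the measured compounds is a 1.1-fold lower number from compound 1 to compound 3 (0.02 log units; within the scatter), and it concerns the amine at the end of the chain, not the aryl group on the five-membered ring.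

Compound 4 `COc1cc2c(Oc3ccc(NC(=O)c4nnn(-c5cccc(Br)c5)c4C(F)(F)F)cc3F)ccnc2cc1OCCCN1CCC(C)CC1` differs from compound 3 by 3-bromophenyl in place of 2-(trifluoromethyl)phenyl on an aromatic nitrogen. Going by the values given here, no measured step touches this position. Compound 2, which carries a plain phenyl together with a methyl on the ring, and compound 3 give numbers within the scatter of each other, but they differ in two places, so that pair gives no clean reading on the aryl group alone. With nothing pointing either way, the expected step of no change at the digits printed from compound 3 to compound 4 (within the scatter) is none beyond the scatter, and compound 4 is estimated at 200 nM, with a range from 80 nM to 500 nM.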

Compound 4, half-maximal inhibitory concentration: 380 nM
The estimate for compound 4 lay 1.9-fold (0.28 log units) below the measured number; measured number inside the range.
By their numbers in this assay, from the lowest: compounds 2, 3, 1 and 4 (each within the scatter of the next, the first and the last beyond it).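

In this assay, for the compounds shown here, the first reading at the aryl group on the aromatic nitrogen is a 1.9-fold higher number from compound 3 to compound 4 (0.28 log units; within the scatter). This step replaces 2-(trifluoromethyl)phenyl, with 10 heavy atoms, by 3-bromophenyl, with 7, and the two compounds remain within the scatter, so this pair gives no sign that the position is sensitive to this exchange of aryl groups. No measurement is available that would account for the size of this step.

Open, on these data alone, is whether a phenyl ring carrying a nitrile or a methoxy group, or a pyridine ring, on this nitrogen would give a step beyond the scatter. Also open, as far as these compounds go, is whether the same aryl exchange reads alike with pyrrolidin-1-yl in place of 4-methylpiperidin-1-yl at the end of the chain.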